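The compounds below may be only part of what the source reports. "The series", "measured", "known", "first", "only" and "open" are said of these compounds alone.

Series notes. The shared core of compound 1 `CC(C)(C)c1ccc(C(=O)N2CCC3(CC2)C(=O)N(CC(=O)N2CCN(S(C)(=O)=O)CC2)CN3c2ccccc2)cc1` carries a 4-(methylsulfonyl)piperazin-1-yl group on a carbonyl carbon whose other neighbour is a saturated chain carbon. In an assay on HEK293 cells for displacement of a labelled ligand from NPC1-like intracellular cholesterol transporter 1 (Homo sapiens) (on this read-out lower numbers stand for stronger inhibition and higher numbers for weaker inhibition), compound 1 gives 19000 nM, the highest number among the three compounds measured. Compound 2 `CC(C)(C)OC(=O)NC1CCCN(C(=O)CN2CN(c3ccccc3)C3(CCN(C(=O)c4ccc(C(C)(C)C)cc4)CC3)C2=O)C1` gives 4200 nM in this assay, and compound 3 `CC1CCCN(C(=O)CN2CN(c3ccccc3)C3(CCN(C(=O)c4ccc(C5CCCCC5)cc4)CC3)C2=O)C1` gives 3600 nM; both gaps from compound 1 lie beyond the scatter, so compound 1 is the weakest inhibitor of the three measured. Compounds 2 and 3 differ from compound 1 in more than one place, and their pair gives no single-point comparison.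

Compound 4 `CC(C)(C)c1ccc(C(=O)N2CCC3(CC2)C(=O)N(CC(=O)N2CCC(O)CC2)CN3c2ccccc2)cc1` is not yet measured. It differs from compound 1 by 4-hydroxypiperidin-1-yl in place of 4-(methylsulfonyl)piperazin-1-yl on a carbonyl carbon. Within the data shown here, no measured pair isolates this change. The only hint is that both compounds carrying a piperidine-type amide, compound 2 at 4200 nM and compound 3 at 3600 nM, give lower numbers than compound 1 at 19000 nM, though other parts of those molecules differ as well. A moderate step toward lower numbers is expected from compound 1 to compound 4 in this assay, a 2.4-fold lower number from compound 1 to compound 4 (0.38 log units; beyond the scatter), smaller than the gap to compound 2 and with wide uncertainty. Compound 4 is estimated at 8000 nM, with a range from 3000 nM to 25000 nM.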

Compound 4, half-maximal inhibitory concentration: 4700 nM
Compound 4: the middle estimate sits 1.7-fold (0.23 log units) above what was measured; the measured number falls inside the stated range.
By their numbers in this assay, from the lowest: compounds 3, 2 and 4 (each within the scatter of the next); then compound 1.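

Among these compounds, the change from 4-(methylsulfonyl)piperazin-1-yl to 4-hydroxypiperidin-1-yl, on a carbonyl carbon whose other neighbour is a saturated chain carbon, gives a 4.0-fold lower number from compound 1 to compound 4 (0.61 log units; beyond the scatter) in this assay, and it is the first step that reads one place alone. The number at this position therefore depends on the group carried there, with the rest of compound 1 held fixed, whereas compound 2 and compound 3 differ from compound 1 in more than one place and could not show this. The change replaces a whole group, so the loss of the methylsulfonyl group, the loss of the second ring nitrogen and the gain of the hydroxyl all arrive together, and nothing at hand accounts for the step.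

Which of these parts carries the step stays open: a plain piperidin-1-yl on the same carbonyl carbon would separate the loss of the methylsulfonyl group from the gain of the hydroxyl, and a 4-aminopiperidin-1-yl or a piperidine bearing a carboxylic acid would test other groups in the hydroxyl's place. As far as these compounds go, whether the step holds when the other parts of the molecule change also remains unknown.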